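Dropping the Hydroxy Group from Compound 3

This account rests on a few compounds, and the source may have more. Where it says the series, first, only, none or still open, it means among the compounds named here.

In an assay on membranes from brain for displacement of a labelled ligand from Sigma non-opioid intracellular receptor 1 (Cavia porcellus), read by scintillation counting, with a stated time of 1 h (a higher number here means a weaker inhibitor, a lower number a stronger inhibitor), compound 3 `O=C(NCCCCN1CCC(Cc2ccccc2)CC1)c1ccc(CO)cc1` has the highest number of the three compounds measured: compound 3 gives 711 nM, whereas compound 1 `O=C(NCCCCN1CCC(Cc2ccccc2)CC1)c1ccc(CO[N+](=O)[O-])cc1` gives 250 nM and compound 2 `O=C(NC1CCN(Cc2ccccc2)CC1)c1ccc(CO[N+](=O)[O-])cc1` gives 22 nM. Going by the values given here, the single measured step, a 2.8-fold higher number from compound 1 to compound 3 (0.45 log units; beyond the scatter), changed the same saturated carbon and made the number larger.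

Compound 4 `Cc1ccc(C(=O)NCCCCN2CCC(Cc3ccccc3)CC2)cc1` differs from compound 3 by hydrogen in place of hydroxy on a saturated chain carbon bound to an aromatic carbon. Among the compounds with values here, no measured step removes a hydroxy group outright, so the only guide is the earlier change at this carbon, a 2.8-fold higher number from compound 1 to compound 3 (0.45 log units; beyond the scatter), which was modest. A modest shift in the other direction seems plausible, but with little certainty. Compound 4 is therefore expected to give about 300 nM, between 100 nM and 900 nM. This expected change is a 2.4-fold lower number from compound 3 to compound 4 (0.37 log units; beyond the scatter).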

Compound 4, inhibition constant: 62 nM
Compound 4: middle estimate off by 4.8-fold (0.68 log units), on the high side, and the stated range ends above it.
By their numbers in this assay, from the lowest: compound 2; then compound 4; then compound 1; then compound 3.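

Hydrogen in place of hydroxy brings an 11-fold lower number from compound 3 to compound 4 (1.06 log units; beyond the scatter), and hydrogen in place of nitrooxy brings a 4.0-fold lower number from compound 1 to compound 4 (0.61 log units; beyond the scatter), so in this assay this saturated chain carbon tolerates losing its oxygen-bearing group and the number falls. Of the three groups compared here, the plain methyl of compound 4 gives the lowest number, which the hydroxymethyl and nitrooxy compounds alone could not show. Nothing available explains this difference. Still open, going by these compounds, is how an amine, a carboxylic acid or a longer chain at this carbon would compare with methyl.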